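Swapping the aryl group on the ether oxygen of compound 2

This account rests on a few compounds, and the source may have more. Where it says the series, first, only, none or still open, it means among the compounds named here.

Compound 2 `Cc1cc(Br)c(Oc2nc(Nc3ccc(C#N)cc3)nc3ccccc23)c(Br)c1` and compound 1 `N#Cc1ccc(Nc2nc(Oc3ccccc3Cl)c3ccccc3n2)cc1` share one core and differ only in the aryl ring carried on the oxygen. Among the measured compounds shown here, in an ADME assay on MT4 cells (Homo sapiens) for cytotoxicity, read by MTT assay, with a stated time of 4 days (a lower number here means that less compound is tolerated, a higher number that more compound is tolerated), compound 2 gives 25000 nM, and compound 1 gives 38000 nM; compound 2 thus sits within the scatter of the only other measured compound. Compound 3 `N#Cc1ccc(Nc2nc(Oc3ccc(Br)cc3)c3ccccc3n2)cc1` is the next case, made from compound 2 by 4-bromophenyl in place of 2,6-dibromo-4-methylphenyl on an oxygen on an aromatic ring. For the measured compounds named here, the one measured step that bears on this change, a 1.5-fold lower number from compound 1 to compound 2 (0.18 log units; within the scatter), also swapped the aryl ring on that oxygen and stayed within the scatter. On that basis no step beyond the scatter is expected for compound 3, so the estimated step is a 1.2-fold higher number from compound 2 to compound 3 (0.08 log units; within the scatter). Compound 3 is therefore expected to give about 30000 nM in this assay, with a likely range from 12000 nM to 80000 nM.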

Compound 3, half-maximal cytotoxic concentration: 215000 nM
The estimate for compound 3 lay 7.2-fold (0.86 log units) below the measured number, outside the stated range (above it).
By their numbers in this assay, from the lowest: compounds 2 and 1 (each within the scatter of the next); then compound 3.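

In this assay the aryl ring on the oxygen can clearly change the number: 4-bromophenyl gives an 8.6-fold higher number from compound 2 to compound 3 (0.93 log units; beyond the scatter) and also a 5.7-fold higher number from compound 1 to compound 3 (0.75 log units; beyond the scatter) when it replaces the other ring. Among the compounds shown here, the earlier swap, a 1.5-fold lower number from compound 1 to compound 2 (0.18 log units; within the scatter) between 2-chlorophenyl and 2,6-dibromo-4-methylphenyl, gave no sign of this, so compound 3 is the first case showing that this position is not indifferent to the ring it carries, with more compound tolerated for the 4-bromophenyl ring. Nothing available explains why this ring stands apart from the other two.

On these data alone, it remains open whether the bromine itself matters, or whether a plain phenyl ring would give a similar number. Also open, as far as these compounds go, is how an amine or a carboxylic acid on that ring, or a cyclohexyl group in its place, would read in this cell test.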